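This account rests on a few compounds, and the source may have more. Where it says the series, first, only, none or still open, it means among the compounds named here.

Compound 1 `CCn1cc(-c2nc3ccccc3[nH]2)c(=O)c2cc(F)c(N3CCNCC3)cc21` gives > 10000 nM in a functional assay on HepG2 cells (Homo sapiens) for cytotoxicity, read by sulforhodamine B assay, with a stated time of 48 h (a lower number here means a stronger inhibitor of growth, a higher number a weaker inhibitor of growth), which is a limit of the assay, not a measured number. Compound 2 `CCn1cc(-c2nc3ccc([N+](=O)[O-])cc3[nH]2)c(=O)c2cc(F)c(N3CCNC(C)C3)c(F)c21` gives 1500 nM in this assay. Compound 3 `CCn1cc(-c2nc3ccc([N+](=O)[O-])cc3s2)c(=O)c2cc(F)c(N3CCNC(C)C3)c(F)c21` gives 900 nM in this assay.

Among these three, compound 1 stands apart: its reading is the one limit value, as the limit of > 10000 nM in this assay, at which 1 of the 3 values shown sits, records, so for compound 1 no number is known. Within the data shown here, compounds 2 and 3 differ from compound 1 in several places at once, so their numbers cannot be traced back to any single change; they show only that related compounds can give measurable values in this assay.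

Compound 4 `CCn1cc(-c2nc3ccc(N)cc3[nH]2)c(=O)c2cc(F)c(N3CCNCC3)cc21` has not yet been tested. It differs from compound 1 in a single place: amino in place of hydrogen on an aromatic carbon. Among the measured compounds shown here, no measured pair isolates this change, so the size of the step is uncertain. A modest move toward stronger inhibition is expected, an at least 1.2-fold lower number from compound 1 to compound 4 (0.09 log units; that floor lies within the scatter), though it may not carry the value clear of the limit. For compound 4 a value of about 8000 nM is expected, estimated to fall between 2000 nM and 30000 nM.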

Compound 4, concentration for 50% growth inhibition: > 10000 nM
Compound 4: a limit, no number (the forecaster's own chance of this, stated with the estimate: 50%); middle value at least 1.2-fold (0.09 log units) from the limit.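

No step can be read from compound 1 to compound 4, because both readings are limits of the assay and not numbers: the limit of > 10000 nM in this assay, at which 2 of the 4 values shown sit. The compounds shown leave open whether amino in place of hydrogen on an aromatic carbon changes growth inhibition at all in this assay.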